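This account rests on a few compounds, and the source may have more. Where it says the series, first, only, none or still open, it means among the compounds named here.

Compound 1 `O=C(Cn1c(=O)oc2cc([N+](=O)[O-])ccc21)Nc1ccccn1` is the strongest of the three compounds measured in an ADME assay on RAW264.7 cells (Mus musculus) for cytotoxicity, read by MTT assay, with a stated time of 72 h, tested at 100 uM (a higher number here means a stronger effect of the compound at the concentration tested, a lower number a weaker effect), where compound 1 gives 47.3%. Its nearest neighbour on the numbers is compound 3 `O=C(Cn1c(=O)oc2ccccc21)Nc1ccccn1`, which in this assay gives 28.4%; the single-point change between them, hydrogen in place of nitro on an aromatic carbon, is read as a number 18.9 percentage points lower from compound 1 to compound 3 (beyond the scatter). Furthest away is compound 2 `O=C(Cn1c(=O)oc2ccccc21)Nc1cc(C(F)(F)F)ccc1Cl`, which gives 15.4%; compound 2 and compound 3 share the core without the nitro group but carry different groups on the amide nitrogen, and no single step links them.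

The unmeasured compound 4 `O=C(Cn1c(=O)oc2cc([N+](=O)[O-])ccc21)NCc1cccs1` keeps the nitro-bearing core of compound 1 and differs only at the amide nitrogen: (thiophen-2-yl)methyl in place of pyridin-2-yl on an amide-type nitrogen. Among the compounds with values here, no measured step touches this position, so the only guide is the spread of the three values, which all lie within a modest band. A small downward step is therefore expected, a number 11.3 percentage points lower from compound 1 to compound 4 (beyond the scatter), with wide uncertainty. Compound 4 is estimated at 36%, in a range from 16% to 56%.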

Compound 4, a percentage reported as inhibition, at one concentration (the size of the read-out at that concentration, not a potency): 41%
The estimate for compound 4 lay 5 percentage points below the measured number; measured number inside the range.
By their numbers in this assay, from the lowest: compound 2; then compound 3; then compounds 4 and 1 (each within the scatter of the next).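

In this assay, within the data shown here, the change at the amide-type nitrogen reads as a number 6.3 percentage points lower from compound 1 to compound 4 (within the scatter) for (thiophen-2-yl)methyl in place of pyridin-2-yl, the first step at this position that can be read. This exchange of a six-membered aromatic ring with one nitrogen for a five-membered aromatic ring with one sulfur, at an equal count of heavy atoms, does not separate the two compounds, whereas the earlier step at the nitro group lay beyond the scatter. No available evidence bears on why this is so.

The compounds shown leave open how the number responds to groups of another kind on this nitrogen, such as a carboxylic acid, an amine or a longer chain. They also leave open what (thiophen-2-yl)methyl gives on the core without the nitro group.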